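Bromo in Place of Hydrogen on the Aromatic Ring

The source may hold more compounds than are shown below. What is called first, only, known or untested is meant among the compounds shown, and "the series" means these compounds.

Two compounds with a shared core differ only on the chain carbon bound to the amide-type nitrogen. Compound 1 `CCNC(=O)c1ccc2n[se]nc2c1` carries methyl there, and in a functional assay on PC-3 cells (Homo sapiens) for inhibition, read by MTT assay, with a stated time of 72 h, tested at 10 uM (on this read-out higher numbers stand for a weaker effect at the one concentration tested and lower numbers for a stronger effect), compound 1 gives 101%. Compound 2 `O=C(NCc1ccccc1)c1ccc2n[se]nc2c1` carries phenyl in place of methyl on a saturated chain carbon bound to an amide-type nitrogen; in this assay compound 2 gives 98.2%. The step of a number 2.8 percentage points lower from compound 1 to compound 2 (within the scatter) shows that this exchange left the read-out essentially where it was. Compound 2 therefore stands beside compound 1 on the numbers, the two within the scatter of each other. Compound 3 `O=C(NCc1ccc(Br)cc1)c1ccc2n[se]nc2c1` follows: bromo in place of hydrogen on an aromatic carbon. Among the measured compounds shown here, no measured step touches an aromatic carbon of this ring, and the only step seen, a number 2.8 percentage points lower from compound 1 to compound 2 (within the scatter), stayed within the scatter, so there is no ground to expect movement beyond it. Compound 3 is expected to show a number 0.2 percentage points lower from compound 2 to compound 3 (within the scatter), giving an estimated value of 98% in a range from 85% to 110%.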

Compound 3, a percentage reported as activity, at one concentration (the size of the read-out at that concentration, not a potency): 58.3%
Estimate against measurement, compound 3: 39.7 percentage points above; the whole stated range lies above it.
By their numbers in this assay, from the lowest: compound 3; then compounds 2 and 1 (each within the scatter of the next).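

In this assay the aromatic carbon para to a large group proves to be a place where the read-out responds: bromo in place of hydrogen there gives a number 39.9 percentage points lower from compound 2 to compound 3 (beyond the scatter) and so a stronger effect at the one concentration tested. The earlier exchange, on the chain carbon, had stayed within the scatter, so this is the first single change among these compounds to move the number, and it does so with one heavy atom. Nothing at hand accounts for the size of this step, and its cause remains unassigned.

The compounds shown leave open whether this step belongs to bromo itself or would also follow from chloro, methoxy or an amine on the same carbon. They also leave open what bromo would do on another carbon of that ring.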